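The source may hold more compounds than are shown below. What is called first, only, known or untested is meant among the compounds shown, and "the series" means these compounds.

Measured so far in a functional assay on COLO 205 cells (Homo sapiens) for inhibition, read by sulforhodamine B assay; a lower number here means a stronger inhibitor of growth, a higher number a weaker inhibitor of growth:
- compound 1 `Cc1ccc2[nH]c(-c3ccc(-c4ccc(-c5ccc(N(C)C)cc5)cc4)cc3)nc2c1`: 9210 nM
- compound 2 `Oc1cccc2[nH]c(-c3ccc(-c4ccc(-c5ccc(F)cc5)cc4)cc3)nc12`: 1220 nM
- compound 3 `Oc1cccc2[nH]c(-c3ccc(-c4ccc(-c5ccc(OC(F)(F)F)cc5)cc4)cc3)nc12`: 8320 nM

Compound 3, at 8320 nM, lies within the usual scatter of compound 1, at 9210 nM, so these two cannot be told apart in this assay. Compound 2 is clearly separated from compound 3, as a 6.8-fold higher number from compound 2 to compound 3 (0.83 log units; beyond the scatter) shows.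

The next compound, compound 4 `Cc1ccc2[nH]c(-c3ccc(-c4ccc(-c5ccc(OC(F)(F)F)cc5)cc4)cc3)nc2c1`, keeps the trifluoromethoxy group of compound 3 but has 5-methyl-1H-benzimidazol-2-yl in place of 4-hydroxy-1H-benzimidazol-2-yl on an aromatic carbon.

Among the compounds with values here, no measured step isolates this exchange. The only one, a 6.8-fold higher number from compound 2 to compound 3 (0.83 log units; beyond the scatter), replaces fluoro with trifluoromethoxy elsewhere in the molecule. It cannot give a direction here, though it does show that a single change in this small set can move the number beyond the scatter, so the range must stay wide. The closest guide is compound 1, which already carries 5-methyl-1H-benzimidazol-2-yl and gives 9210 nM, although it differs from compound 4 elsewhere too.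

No shift beyond the scatter is therefore expected, and the estimated change is a 1.0-fold higher number from compound 3 to compound 4 (0.01 log units; within the scatter). For compound 4 the estimated value in this assay is 8500 nM, with an expected range from 2800 nM to 26000 nM.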

Compound 4, concentration for 50% growth inhibition: 30600 nM
The estimate for compound 4 lay 3.6-fold (0.56 log units) below the measured number; measured number above the stated range.
By their numbers in this assay, from the lowest: compound 2; then compounds 3 and 1 (each within the scatter of the next); then compound 4.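

Compound 3 and compound 4 differ only in the benzimidazole group, so this exchange can now be read directly in this assay: swapping 4-hydroxy-1H-benzimidazol-2-yl for 5-methyl-1H-benzimidazol-2-yl gives a 3.7-fold higher number from compound 3 to compound 4 (0.57 log units; beyond the scatter), which means that this part of the molecule affects growth inhibition with the trifluoromethoxy group held fixed. With 5-methyl-1H-benzimidazol-2-yl held fixed instead, trifluoromethoxy in place of dimethylamino gives a 3.3-fold higher number from compound 1 to compound 4 (0.52 log units; beyond the scatter), so the group at the other end of the molecule also moves the number in this methyl-bearing pair. No measurement available here explains either step.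

The exchange removes a hydroxy group and adds a methyl group in one move, so the compounds shown cannot say which part drives the higher number, or what an unsubstituted 1H-benzimidazol-2-yl, or one carrying an amine or a methoxy group, would give. Going by these compounds, it also remains open whether the same exchange would move the number by a similar amount with the fluoro group of compound 2 in place of trifluoromethoxy.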